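A few compounds are considered here, and "the series" means these few. Any claim that something is new, unique, unknown or untested is made for them only; others in the source may bear on it.

The series keeps the core of compound 1 `O=C(COCc1cnccn1)N1CCN(c2ccc(Cl)cc2Cl)CC1` and varies the aromatic group on the saturated chain carbon bound to an oxygen on a saturated carbon. In a functional assay on HEK293 cells for positive allosteric modulation of metabotropic glutamate receptor 5 (Homo sapiens), read by FLIPR and calcium flux (on this read-out lower numbers stand for an effect already at smaller amounts and higher numbers for an effect only at larger amounts of compound), compound 1 gives 5200 nM. Compound 2 `O=C(COCc1cncs1)N1CCN(c2ccc(Cl)cc2Cl)CC1`, with 1,3-thiazol-5-yl in place of pyrazin-2-yl, gives 1280 nM in this assay; the step of a 4.1-fold lower number from compound 1 to compound 2 (0.61 log units; beyond the scatter) is the only fully readable one in the set. Compound 3 `O=C(COCc1cccs1)N1CCN(c2ccc(Cl)cc2Cl)CC1` carries thiophen-2-yl at the same place. For compound 3 this assay records only a limit, > 310 nM. That is why a step that the limit leaves unreadable from compound 1 to compound 3 and a step that the limit leaves unreadable from compound 2 to compound 3 cannot be sized; the reason is the limit of > 310 nM in this assay, at which 1 of the 3 values shown sits. Compound 3 thus stands at the edge of what the numbers shown can place.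

Compound 4 `N#Cc1ccc(COCC(=O)N2CCN(c3ccc(Cl)cc3Cl)CC2)s1` differs from compound 3 by cyano in place of hydrogen on an aromatic carbon. Among the measured compounds shown here, no measured step touches a substituent on this ring; the one readable step, a 4.1-fold lower number from compound 1 to compound 2 (0.61 log units; beyond the scatter), concerns an exchange of the whole ring and does not carry over. The step that the limit leaves unreadable from compound 3 to compound 4 that the estimate implies cannot be anchored to a number, as compound 3 offers only a limit. Compound 4 is therefore estimated at 1500 nM in this assay, within 300 nM to 8000 nM, and a limit rather than a number remains a live possibility.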

Compound 4, half-maximal effective concentration: 210 nM
Estimate against measurement, compound 4: 7.1-fold (0.85 log units) above, and the stated range ends above it.
By their numbers in this assay, from the lowest: compound 4; then compound 2; then compound 1.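

Cyano in place of hydrogen, on an aromatic carbon next to the ring sulfur, is the first change in the series to a substituent on the ring rather than to the ring as a whole. Against the two rings with full values in this assay, 5-cyanothiophen-2-yl gives a 6.1-fold lower number from compound 2 to compound 4 (0.78 log units; beyond the scatter) and a 25-fold lower number from compound 1 to compound 4 (1.39 log units; beyond the scatter), so a substituent at this place is compatible with the lowest number among compound 1, compound 2 and compound 4. Compound 3 has only a limit, so the direct step reads only as an at least 1.4-fold lower number from compound 3 to compound 4 (0.16 log units; that floor lies within the scatter), and the contribution of the cyano group itself has no size: the limit of > 310 nM in this assay, at which 1 of the 4 values shown sits.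

Open, on these data alone, is whether another group at this place, such as fluorine, methyl, a carboxamide or a carboxylic acid, would read like cyano, and whether cyano on the 1,3-thiazol-5-yl ring of compound 2 or the pyrazin-2-yl ring of compound 1 would lower those numbers as well. The steps from compound 1 and from compound 2 to compound 3 also remain unreadable, which leaves the place of the unsubstituted thiophen-2-yl group among these rings unsettled.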